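This account rests on a few compounds, and the source may have more. Where it says the series, first, only, none or still open, it means among the compounds named here.

Of the compounds shown here, three sharing one core have been measured in a functional assay on Ehrlich cells (Mus musculus) for cytotoxicity, read by trypan blue exclusion, with a stated time of 2 h, tested at 100 ug/mL; on this read-out higher numbers stand for a stronger effect at the one concentration tested and lower numbers for a weaker effect. Compound 1 `C=CCNC(=S)NC1=C(C#N)C(c2ccc(Cl)cc2Cl)C2=C(CCCC2=O)N1c1ccc(S(N)(=O)=O)cc1` gives 40%. Compound 2 `N#CC1=C(NC(=S)Nc2ccccc2)N(c2ccc(S(N)(=O)=O)cc2)C2=C(C(=O)CCC2)C1c1ccc(Cl)cc1Cl` gives 95%, and compound 3 `N#CC1=C(NC(=S)Nc2ccc(Br)cc2)N(c2ccc(S(N)(=O)=O)cc2)C2=C(C(=O)CCC2)C1c1ccc(Cl)cc1Cl` gives 90%, which lies within the scatter of compound 2 and well above compound 1, as shown by a number 50 percentage points higher from compound 1 to compound 3 (beyond the scatter). Compound 4 `N#CC1=C(NC(N)=O)N(c2ccc(S(N)(=O)=O)cc2)C2=C(C(=O)CCC2)C1c1ccc(Cl)cc1Cl` is not yet measured; it differs from compound 3 in that (a group of 3 heavy atoms (1 carbon, 1 nitrogen, 1 oxygen; no ring) in place of a group of 10 heavy atoms (7 carbon, 1 nitrogen, 1 sulfur, 1 bromine; one six-membered aromatic ring of carbon only), on an amine nitrogen). Among the measured compounds shown here, the steps that bear on this change are a number 55 percentage points higher from compound 1 to compound 2 (beyond the scatter) and a number 50 percentage points higher from compound 1 to compound 3 (beyond the scatter): on that nitrogen a group holding one six-membered aromatic ring of carbon only went with a far higher number than allyl did. Taking such a ring away is therefore expected to lower the number, and compound 4 is estimated at 45%, between 20% and 75%, an expected step of a number 45 percentage points lower from compound 3 to compound 4 (beyond the scatter).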

Compound 4, a percentage reported as activity, at one concentration (the size of the read-out at that concentration, not a potency): 60%
Compound 4: middle estimate off by 15 percentage points, on the low side; the range from low to high includes it.
By their numbers in this assay, from the lowest: compound 1; then compound 4; then compounds 3 and 2 (each within the scatter of the next).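

In this assay, carbamoyl on this amine nitrogen gives a number 30 percentage points lower from compound 3 to compound 4 (beyond the scatter) and a number 35 percentage points lower from compound 2 to compound 4 (beyond the scatter), so the groups holding an aromatic ring remain well ahead of it. Yet a number 20 percentage points higher from compound 1 to compound 4 (beyond the scatter) shows that a group without a ring need not sit as low as the allyl-bearing group. Losing the ring therefore does not by itself bring the number down to that of compound 1.

Nothing available explains these differences. Where a plain amine or a carboxylic acid on this nitrogen would fall remains open.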